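This account rests on a few compounds, and the source may have more. Where it says the series, first, only, none or still open, it means among the compounds named here.

Measured so far in a functional assay for inhibition, tested at 0.1 mM; a lower number here means less inhibition, a higher number more inhibition at the concentration tested (going by the name of the read-out):

- compound 1 `Cn1c(Cn2c(-c3ccccc3)nc3ccccc32)n[nH]c1=S`: 5%
- compound 2 `COc1ccc(-c2nc3ccccc3n2Cc2n[nH]c(=S)n2C)cc1`: 5%
- compound 3 `CNC(=S)NNC(=O)Cn1c(-c2ccc(OCc3ccccc3)cc2)nc2ccccc21`: 5%

Compound 3 stands level with compounds 1 and 2 in this assay; its value sits nearest to that of compound 1 and furthest from that of compound 2, and neither gap goes beyond the scatter. For the measured compounds named here, the series so far is flat: the only single-point step, no change at the digits printed from compound 1 to compound 2 (within the scatter), shows no movement at the digits printed.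

The unmeasured compound 4 `Cn1c(Cn2c(-c3ccc(OCc4ccccc4)cc3)nc3ccccc32)n[nH]c1=S` differs from compound 3 in one place: a group of 7 heavy atoms (3 carbon, 3 nitrogen, 1 sulfur; one five-membered aromatic ring with 3 hetero atoms) in place of a group of 8 heavy atoms (3 carbon, 3 nitrogen, 1 oxygen, 1 sulfur; no ring), on a saturated chain carbon bound to an aromatic nitrogen. Going by the values given here, the group that enters is the one already carried by compounds 1 and 2, both of which sit at the same low level as compound 3. Among the compounds with values here, no measured step covers this particular exchange, so the expectation rests on the flatness of the whole set: three compounds, two cores, one substituent change, and no value moving. The step from compound 3 to compound 4 is therefore expected to be no change at the digits printed from compound 3 to compound 4 (within the scatter), nothing beyond the scatter. Compound 4 is estimated at 5% in this assay, in a range from 0% to 15%.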

Compound 4, a percentage reported as inhibition, at one concentration (the size of the read-out at that concentration, not a potency): 5%
Compound 4: middle estimate and measured number agree at the digits printed; the measured number falls inside the stated range.
By their numbers in this assay, from the lowest: compounds 1, 2, 3 and 4 (each within the scatter of the next).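

In this assay, the open group and the five-membered aromatic ring read alike on the saturated chain carbon bound to an aromatic nitrogen, at least with benzyloxy present: no change at the digits printed from compound 3 to compound 4 (within the scatter). With that ring held constant, adding benzyloxy gives no change at the digits printed from compound 1 to compound 4 (within the scatter), and phenyl in place of hydrogen on a saturated chain carbon bound to an oxygen on an aromatic ring gives no change at the digits printed from compound 2 to compound 4 (within the scatter), so the larger group separates from neither hydrogen nor methoxy. Nothing available bears on why the series holds this level.

Still open, from the compounds shown here alone, is whether any change at either position moves the read-out from the level of compound 4 at 5%. An amine or a carboxylic acid in place of benzyloxy, or a longer chain in place of the saturated chain carbon, would test this.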